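The compounds below may be only part of what the source reports. "The series", "measured", "known", "first", "only" and "open" are said of these compounds alone.

In a functional assay on MCF7 cells (Homo sapiens) for cytotoxicity, read by MTT assay, with a stated time of 72 h (on this read-out lower numbers stand for stronger inhibition of growth and higher numbers for weaker inhibition of growth), compound 1 `CS/C(=N\C(=O)c1csc([N+](=O)[O-])c1)NC(=O)c1csc([N+](=O)[O-])c1` gives 44700 nM. Compound 2 `CS/C(=N\C(=O)c1ccno1)NC(=O)c1ccno1` gives 77800 nM in this assay; the two numbers lie within the usual scatter of each other, so no order between compound 1 and compound 2 is claimed, and the difference between the two cores is not broken down here. Compound 3 `O=C(/N=C(/NC(=O)c1ccno1)[Se]Cc1ccccc1)c1ccno1` carries, on the core of compound 2, the change (a group of 8 heavy atoms (7 carbon, 1 selenium; one six-membered aromatic ring of carbon only) in place of a group of 2 heavy atoms (1 carbon, 1 sulfur; no ring), on a carbon with a double bond to nitrogen), and in this assay compound 3 gives 7800 nM, which means a 10-fold lower number from compound 2 to compound 3 (1.00 log units; beyond the scatter).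

Compound 4 `O=C(/N=C(/NC(=O)c1csc([N+](=O)[O-])c1)[Se]Cc1ccccc1)c1csc([N+](=O)[O-])c1` has not yet been measured in this assay. It carries on the core of compound 1 the change (a group of 8 heavy atoms (7 carbon, 1 selenium; one six-membered aromatic ring of carbon only) in place of a group of 2 heavy atoms (1 carbon, 1 sulfur; no ring), on a carbon with a double bond to nitrogen), the same change as that from compound 2 to compound 3, set on the same kind of carbon with the same neighbours. Compound 4 is expected to show a 9.9-fold lower number from compound 1 to compound 4 (1.00 log units; beyond the scatter), a step of about the same size, because the same change gave a 10-fold lower number from compound 2 to compound 3 (1.00 log units; beyond the scatter) on the other core, though that expectation rests on a single measured pair. Compound 4 is therefore estimated at 4500 nM, with a range expected from 1500 nM to 15000 nM.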

Compound 4, concentration for 50% growth inhibition: 24400 nM
Beside the measured number, compound 4's estimate is 5.4-fold (0.73 log units) below it; the measured number lies above the stated range.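

Set beside the earlier step, the change does not carry over at the same size from one core to the other in this assay: the same change on two cores in this assay, a 10-fold lower number (1.00 log units; beyond the scatter) from compound 2 to compound 3 and a 1.8-fold lower number (0.26 log units; within the scatter) from compound 1 to compound 4, 5.4-fold (0.74 log units) apart, beyond the scatter of two such steps

Replacing methylsulfanyl with the selenium-bearing group that holds the six-membered aromatic ring gives a 1.8-fold lower number from compound 1 to compound 4 (0.26 log units; within the scatter), a step that cannot be told apart from repeat measurement. The size of this change therefore depends on the core in these two pairs, but two pairs give no rule for any other core and do not show which part of the cores accounts for the gap.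

The compounds shown leave open whether the selenium atom or the aromatic ring matters more to the step, a question that a benzylsulfanyl or a methylselanyl group on the same carbon could separate. Also open, as far as these compounds go, is how an amine or a longer alkyl chain in that place would read on either core.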